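A few compounds are considered here, and "the series" means these few. Any claim that something is new, unique, unknown or untested is made for them only; others in the source may bear on it.

Compound 1 `COc1cccc(OS(=O)(=O)/C=C/c2ccccc2Cl)c1` gives 165 nM in an assay on U2OS cells for activation of nuclear factor erythroid 2-related factor 2 (Homo sapiens), read by chemiluminescence, with a stated time of 6 h; a higher number here means that more compound is needed for the effect, a lower number that less compound is needed. That is the lower of the two numbers recorded so far, but its companion compound 2 `COc1ccc(OS(=O)(=O)/C=C/c2ccccc2Cl)cc1` gives 237 nM in this assay, and the two values lie within the scatter of each other, so neither can be called the stronger of the pair.

Compound 3 `COc1cccc(OS(=O)(=O)/C=C/c2cccc(Cl)c2)c1` has not yet been measured. It keeps every atom of compound 1 but joins them differently: 3-chlorophenyl in place of 2-chlorophenyl on a double-bonded chain carbon bound to a double-bonded chain carbon. For the measured compounds named here, no measured pair in this small set records the effect of moving a chlorine from one position of that ring to another, so there is no step to lean on. Going by the values given here, the only comparison available, between compound 1 and compound 2, shows a difference that stays within the scatter. The expected step is therefore a 1.3-fold higher number from compound 1 to compound 3 (0.10 log units; within the scatter), small and not clearly beyond the scatter in either direction, with a slight lean toward a higher number. Compound 3 is estimated at 210 nM, with a plausible range from 80 nM to 550 nM.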

Compound 3, half-maximal effective concentration: 943 nM
Compound 3: middle estimate off by 4.5-fold (0.65 log units), on the low side; the measured number lies above the stated range.
By their numbers in this assay, from the lowest: compounds 1 and 2 (each within the scatter of the next); then compound 3.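

In this assay the place of the chlorine on the ring turns out to count: with the atoms unchanged, 3-chlorophenyl in place of 2-chlorophenyl on a double-bonded chain carbon bound to a double-bonded chain carbon gives a 5.7-fold higher number from compound 1 to compound 3 (0.76 log units; beyond the scatter). For the compounds shown here, the earlier pair showed no difference that could be read, so this is the first change in the set that clearly moves the number, and it moves it toward more compound being needed for the effect. Nothing at hand speaks to what lies behind this step, which stands as an observation about this one change on the core of compound 1.

The compounds shown leave open whether the step belongs to the chlorine alone or would recur with a bromine, a methyl or a nitrile on that ring, and how a plain phenyl with no such group would compare with either chlorophenyl. Going by these compounds alone, they also leave open whether the same change would carry the same size with the methoxy group placed as it is in compound 2, since the one step at hand rests on the methoxy group of compound 1.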